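The source may report more compounds than this note shows. Statements on the series, on what has been measured and on what is new or still open speak of the compounds shown alone.

Measured compounds:
Compound 1, `O=C(NC(c1nccs1)C1CCNCC1)c1ccc2cnccc2c1`: in an assay on isolated protein for inhibition of RAC-alpha serine/threonine-protein kinase (Homo sapiens) (on this read-out higher numbers stand for weaker inhibition and lower numbers for stronger inhibition), compound 1 gives 1570 nM.
Compound 2, `N#Cc1cc(C(NC(=O)c2ccc3cnccc3c2)C2CCNCC2)ccc1Cl`: in this assay compound 2 gives 80 nM.

Among the measured compounds shown here, compound 2 stands at the lower of the two numbers measured so far; its nearest neighbour is compound 1, and the step of a 20-fold lower number from compound 1 to compound 2 (1.29 log units; beyond the scatter) lies well beyond the scatter. The two compounds share the same core, and they differ only in the aromatic group on the saturated chain carbon bound to the amide-type nitrogen and the saturated ring carbon.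

Compound 3, `O=C(NC(c1cccc(Cl)c1)C1CCNCC1)c1ccc2cnccc2c1`, has not yet been measured. It arises from compound 2 by the change (3-chlorophenyl in place of 4-chloro-3-cyanophenyl on a saturated chain carbon bound to an amide-type nitrogen and a saturated ring carbon). For the measured compounds named here, the only measured step that bears on this position is a 20-fold lower number from compound 1 to compound 2 (1.29 log units; beyond the scatter), which shows that this group matters strongly. Compound 3 keeps a six-membered carbon ring with chlorine but gives up the nitrile, so a number between those of compound 1 and compound 2 is expected, with the estimated step of a 4.0-fold higher number from compound 2 to compound 3 (0.60 log units; beyond the scatter). For compound 3 the estimate in this assay is therefore 320 nM, with a range from 100 nM to 1000 nM.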

Compound 3, half-maximal inhibitory concentration: 70 nM
Compound 3: the middle estimate sits 4.6-fold (0.66 log units) above what was measured; the whole stated range lies above it.
By their numbers in this assay, from the lowest: compounds 3 and 2 (each within the scatter of the next); then compound 1.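

In this assay the change to 3-chlorophenyl gives a 1.1-fold lower number from compound 2 to compound 3 (0.06 log units; within the scatter), so the 4-chloro-3-cyanophenyl and 3-chlorophenyl groups cannot be told apart at this position on a saturated chain carbon, even though the change both drops the nitrile and puts the chlorine at 3 instead of 4. Set against the thiazole, the same group gives a 22-fold lower number from compound 1 to compound 3 (1.35 log units; beyond the scatter), which shows that the large step seen earlier with 4-chloro-3-cyanophenyl does not depend on the nitrile being present, since a six-membered carbon aromatic ring carrying chlorine alone matches it in this pair of compounds. Nothing measured here explains why the nitrile makes no readable difference or why both chlorophenyl groups stand so far from the thiazole.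

The compounds shown leave open whether the chlorine itself matters, since they do not tell how a plain phenyl or a 3-cyanophenyl group would read on this carbon. They also leave open how a ring carrying an amine or a carboxylic acid in place of the chlorine would stand, and whether 3-chlorophenyl keeps its standing on a different core.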